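This account rests on a few compounds, and the source may have more. Where it says the series, first, only, none or still open, it means among the compounds named here.

Working notes on the series. Compound 3 `COc1ccc(F)c([C@H]2CC[C@H](COc3cccc([C@H](C4CC4)[C@@H](F)C(=O)O)c3)CC2)c1` stands second highest of the three numbers in a functional assay on cells for agonist activity at Free fatty acid receptor 1 (Homo sapiens), read by HTRF and inositol phosphate accumulation, with a stated time of 90 min (a higher number here means that more compound is needed for the effect, a lower number that less compound is needed), where compound 3 gives 20 nM; compound 2 `COc1ccc(F)c([C@H]2CC[C@H](COc3cccc([C@H](C4CC4)[C@@H](C)C(=O)O)c3)CC2)c1` gives 22 nM, and the two lie within the scatter, while compound 1 `COc1ccc(F)c([C@H]2CC[C@H](COc3cccc([C@H](C4CC4)[C@H](C)C(=O)O)c3)CC2)c1` gives 2 nM, a step of a 10-fold higher number from compound 1 to compound 3 (1.00 log units; beyond the scatter).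

Compound 4 `COc1ccc(F)c([C@H]2CC[C@H](COc3cccc([C@H](C4CC4)[C@@](C)(F)C(=O)O)c3)CC2)c1` is the next step: 1-carboxy-1-fluoroethyl in place of carboxy(fluoro)methyl on a saturated chain carbon bound to an aromatic carbon and a saturated ring carbon. The measured steps that bear on it are a 1.1-fold lower number from compound 2 to compound 3 (0.04 log units; within the scatter), which shows that fluoro for methyl at this carbon changes little, and an 11-fold higher number from compound 1 to compound 2 (1.04 log units; beyond the scatter), where the two compounds differ only in configuration (the fact that compounds 1 and 2 differ only in the configuration as drawn), showing that the arrangement at this stereocentre carries a large step. Compound 4 carries both methyl and fluoro on the same carbon, with the methyl drawn in the configuration of compound 1. Since fluoro for hydrogen has not been measured here, the step is expected to lie between no change and the gain seen for compound 1, and the estimate for compound 4 is 6 nM in this assay, range 1.5 nM to 25 nM, a step of a 3.3-fold lower number from compound 3 to compound 4 (0.52 log units; beyond the scatter).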

Compound 4, half-maximal effective concentration: 3.1 nM
The estimate for compound 4 lay 1.9-fold (0.29 log units) above the measured number, and the stated range covers the measured number.
By their numbers in this assay, from the lowest: compounds 1 and 4 (each within the scatter of the next); then compounds 3 and 2 (each within the scatter of the next).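

At this carbon, fluoro and methyl sit together with a lower number in this assay than fluoro alone (a 6.5-fold lower number from compound 3 to compound 4 (0.81 log units; beyond the scatter)) or the other methyl arrangement alone (a 7.1-fold lower number from compound 2 to compound 4 (0.85 log units; beyond the scatter)). Set against the best methyl compound, the added fluoro leaves the number in place (a 1.6-fold higher number from compound 1 to compound 4 (0.19 log units; within the scatter)), so the low number of compound 1 is kept in the 1-carboxy-1-fluoroethyl compound. Both low numbers now belong to compounds with the methyl drawn as in compound 1, which ties the large step to that arrangement and not to the methyl as such: the fact that compounds 1 and 2 differ only in the configuration as drawn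

The compounds shown leave open how the opposite configuration of the 1-carboxy-1-fluoroethyl group would read. They also leave open whether chloro or hydroxyl in place of the fluoro, or ethyl in place of the methyl, would keep the number this low.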